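The source may hold more compounds than are shown below. What is called first, only, known or untested is meant among the compounds shown, and "the series" means these compounds.

- compound 1 `CCOc1ccc(/C=C(/Sc2ccccc2Cl)C(=O)c2ccc(Cl)cc2)cc1OC` gives 50000 nM
- compound 2 `O=C(/C(=C\c1ccc(Oc2ccccc2)cc1)Sc1ccc(Br)cc1)c1ccc(Br)cc1` gives 50000 nM

In a functional assay on DU-145 cells (Homo sapiens) for inhibition, read by trypan blue exclusion, with a stated time of 96 h (on this read-out lower numbers stand for stronger inhibition of growth and higher numbers for weaker inhibition of growth), compound 1 stands level with compound 2, within the scatter. Among the measured compounds shown here, no measured step gives a scale for a single change. Compound 3 `CCOc1ccc(/C=C(\C(=O)c2ccc(Cl)cc2)S(=O)(=O)c2ccc(C)cc2)cc1OC` has (4-methylphenyl)sulfonyl in place of (2-chlorophenyl)sulfanyl on a double-bonded chain carbon bound to a carbonyl carbon and a double-bonded chain carbon. In this assay a modest move toward stronger inhibition of growth is expected (a 2.0-fold lower number from compound 1 to compound 3 (0.30 log units; within the scatter)), though a result within the scatter would not surprise. The estimate for compound 3 is 25000 nM (expected range 3000 nM to 60000 nM).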

Compound 3, concentration for 50% growth inhibition: 1000 nM
Estimate against measurement, compound 3: 25-fold (1.40 log units) above; measured number below the stated range.
By their numbers in this assay, from the lowest: compound 3; then compounds 1 and 2 (each within the scatter of the next).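

In this assay, (4-methylphenyl)sulfonyl in place of (2-chlorophenyl)sulfanyl gives a 50-fold lower number from compound 1 to compound 3 (1.70 log units; beyond the scatter), so this place on a double-bonded chain carbon can carry a large change in growth inhibition. The two earlier compounds, level with each other, gave no such scale. No measurement shown here bears on what lies behind this step. The change replaces the sulfur group and the ring substituents together, and the compounds shown do not separate the sulfonyl from the 4-methylphenyl. From the compounds shown here alone, whether methylsulfonyl or a carboxylic acid at this place would keep the stronger inhibition also stays open.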